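A few compounds are considered here, and "the series" means these few. Any claim that something is new, unique, unknown or untested is made for them only; others in the source may bear on it.

In a functional assay on cells (Homo sapiens) for cytotoxicity, read by MTT assay, with a stated time of 24 h (on this read-out higher numbers stand for weaker inhibition and lower numbers for stronger inhibition), compound 3 `CCCCCCCCCCCCCCNC(=O)[C@H](CO)/N=C/c1ccc([N+](=O)[O-])cc1` gives 217000 nM and stands highest of the three measured numbers, the weakest inhibitor so far. Compound 1 `CCCCCCCCCCCCCCNC(=O)[C@H](CO)/N=C/c1ccc(OC)cc1` gives 28100 nM and compound 2 `CCCCCCCCCCCCCCNC(=O)[C@H](CO)/N=C/c1ccccc1` gives 7670 nM there. Compound 4 `CCCCCCCCCCCCCCNC(=O)[C@H](CO)/N=C/c1ccc(C)cc1` has methyl in place of nitro on an aromatic carbon of compound 3 (methyl in place of nitro on an aromatic carbon). Two measured steps bring nitro in, the large 28-fold higher number from compound 2 to compound 3 (1.45 log units; beyond the scatter) and the modest 7.7-fold higher number from compound 1 to compound 3 (0.89 log units; beyond the scatter) and both raise the number. Taking nitro out is therefore expected to give a modest to large drop in this assay again. The expected change is an estimated 16-fold lower number from compound 3 to compound 4 (1.19 log units; beyond the scatter). For compound 4 the estimate is 14000 nM with an expected range from 5000 nM to 40000 nM on this reasoning.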

Compound 4, half-maximal inhibitory concentration: 102000 nM
Beside the measured number, compound 4's estimate is 7.3-fold (0.86 log units) below it; the measured number lies above the stated range.
By their numbers in this assay, from the lowest: compound 2; then compound 1; then compound 4; then compound 3.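

In this assay the step with methyl in place of hydrogen, a 13-fold higher number from compound 2 to compound 4 (1.12 log units; beyond the scatter) and still large, shows that a higher number at this position does not belong to nitro alone, and compound 2 remains the strongest inhibitor of the four. Methyl in place of nitro gives only a 2.1-fold lower number from compound 3 to compound 4 (0.33 log units; beyond the scatter) and methyl in place of methoxy gives a 3.6-fold higher number from compound 1 to compound 4 (0.56 log units; beyond the scatter) so methyl ranks between methoxy and nitro here. Nothing available explains this order. On these data alone, whether an amine or a chlorine at this position would also stand above hydrogen remains open. So does whether a longer chain would shift these numbers.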